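Replacing trifluoromethyl with methoxy in the series

The source may report more compounds than this note shows. Statements on the series, on what has been measured and on what is new or still open speak of the compounds shown alone.

Measured in a functional assay on COLO 205 cells (Homo sapiens) for inhibition, read by sulforhodamine B assay; on this read-out higher numbers stand for weaker inhibition of growth and lower numbers for stronger inhibition of growth:
compound 1 `COc1ccc(-c2ccc(-c3ccc(-c4nc5cc(C)ccc5[nH]4)cc3)cc2)cc1OC`: 2320 nM
compound 2 `Fc1ccc(-c2ccc(-c3ccc(-c4nc5ccccc5[nH]4)cc3)cc2)cc1`: 100000 nM
compound 3 `FC(F)(F)c1ccc(-c2ccc(-c3ccc(-c4nc5ccccc5[nH]4)cc3)cc2)cc1`: 33900 nM

Compound 3 stands second highest of the three numbers, with compound 2 above it and compound 1 well below it. The change to compound 4 `COc1ccc(-c2ccc(-c3ccc(-c4nc5ccccc5[nH]4)cc3)cc2)cc1` is methoxy in place of trifluoromethyl on an aromatic carbon. Within the data shown here, the one measured step that bears on it is a 2.9-fold lower number from compound 2 to compound 3 (0.47 log units; beyond the scatter), trifluoromethyl in place of fluoro. Among the measured compounds shown here, compound 1, at 2320 nM, is the only measured compound carrying methoxy, but it also differs elsewhere from compound 4, so it offers limited guidance. A modest move to a lower number is expected in this assay, and the estimated step is a 2.8-fold lower number from compound 3 to compound 4 (0.45 log units; beyond the scatter). For compound 4 the expected value is 12000 nM, with an estimated range of 4000 nM to 40000 nM.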

Compound 4, concentration for 50% growth inhibition: 45200 nM
Beside the measured number, compound 4's estimate is 3.8-fold (0.58 log units) below it, and the stated range ends below it.
By their numbers in this assay, from the lowest: compound 1; then compounds 3 and 4 (each within the scatter of the next); then compound 2.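

In this assay this position does not separate trifluoromethyl from methoxy: a 1.3-fold higher number from compound 3 to compound 4 (0.12 log units; within the scatter). Fluoro is the group that stands apart here, with a 2.2-fold lower number from compound 2 to compound 4 (0.34 log units; beyond the scatter), so the two larger groups share one level and compound 2 stands above it. Nothing available accounts for this match between trifluoromethyl and methoxy.

Open, as far as these compounds go, is whether an amine or a carboxylic acid at this position would stay level with compound 3 and compound 4. Also open, from the compounds shown here alone, is whether the same exchange holds on the core of compound 1.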